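The source may hold more compounds than are shown below. What is called first, only, known or untested is meant among the compounds shown, and "the series" means these compounds.

The three measured compounds share one core and differ only in the group carried on it. In an assay for binding affinity to dual specificity mitogen-activated protein kinase kinase 4 (Homo sapiens), read by KINOMEscan, tested at 100 nM (on this read-out lower numbers stand for a stronger effect and higher numbers for a weaker effect at the one concentration tested), compound 1 `CCCS(=O)(=O)Nc1ccc(F)c(C(=O)c2n[nH]c3ncc(-c4cccc(OC)c4)cc23)c1F` gives 6.3%. Compound 2 `CCCS(=O)(=O)Nc1ccc(F)c(C(=O)c2n[nH]c3ncc(-c4ccccc4N)cc23)c1F` gives 23% in this assay, a number 16.7 percentage points higher from compound 1 to compound 2 (beyond the scatter). Compound 3 `CCCS(=O)(=O)Nc1ccc(F)c(C(=O)c2n[nH]c3ncc(-c4cccc([N+](=O)[O-])c4)cc23)c1F` gives 15% in this assay. Compound 3 stands second highest of the three numbers: the nearest is compound 2, with a number 8 percentage points lower from compound 2 to compound 3 (within the scatter), and the furthest is compound 1, with a number 8.7 percentage points higher from compound 1 to compound 3 (within the scatter), so neither neighbour is separated from it beyond the scatter.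

Compound 4 `CCCS(=O)(=O)Nc1ccc(F)c(C(=O)c2n[nH]c3ncc(-c4ccc(S(N)(=O)=O)cc4Cl)cc23)c1F` has not yet been measured. It differs from compound 3 in one place: 2-chloro-4-sulfamoylphenyl in place of 3-nitrophenyl on an aromatic carbon. For the measured compounds named here, no measured step touches either a sulfamoyl or a chloro group; the only steps available vary the group at the same position, two of them lie within the scatter, and a number 16.7 percentage points higher from compound 1 to compound 2 (beyond the scatter) is the one modest shift. On that basis, for compound 4 the expected change is a number 1 percentage points higher from compound 3 to compound 4 (within the scatter), no shift beyond the scatter. Compound 4 is therefore estimated to give 16% in this assay, with a range from 5% to 35%.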

Compound 4, a percentage reported as activity, at one concentration (the size of the read-out at that concentration, not a potency): 3.4%
Compound 4: the middle estimate sits 12.6 percentage points above what was measured; the whole stated range lies above it.
By their numbers in this assay, from the lowest: compounds 4, 1, 3 and 2 (each within the scatter of the next, the first and the last beyond it).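

In this assay the 2-chloro-4-sulfamoylphenyl group, the only group shown with two substituents on its phenyl ring, gives a number 11.6 percentage points lower from compound 3 to compound 4 (beyond the scatter) and a number 19.6 percentage points lower from compound 2 to compound 4 (beyond the scatter) at this position on the shared core. Set against the 3-methoxyphenyl group, the same change gives a number 2.9 percentage points lower from compound 1 to compound 4 (within the scatter) and so joins that group at the low end of the numbers, which shows that this position can carry a chloro and a sulfamoyl group together without a rise in the number. Nothing measured here explains these steps.

The compounds shown leave open how the step divides between the chloro and the sulfamoyl group. They also leave open whether a methylsulfonyl group or a carboxylic acid in place of the sulfamoyl group, or a fluorine in place of the chlorine, would give a similar number.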